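A few compounds are considered here, and "the series" means these few. Any claim that something is new, unique, unknown or untested is made for them only; others in the source may bear on it.

Of the compounds shown here, three built on a shared core have been tested in a functional assay on A-375 cells (Homo sapiens) for antiproliferative activity, read by CCK-8 assay, with a stated time of 72 h, tested at 2 uM; on this read-out lower numbers stand for a weaker effect and higher numbers for a stronger effect at the one concentration tested. Compound 1 `Nc1ccccc1NC(=O)c1ccc(CSC(=S)N2CCN(c3ccc(Cl)cc3)CC2)cc1` gives 32.2%. Compound 2 `COc1ccc(N2CCN(C(=S)SCc3ccc(C(=O)Nc4ccccc4N)cc3)CC2)cc1` gives 28.1%. Compound 3 `CN1CCN(C(=S)SCc2ccc(C(=O)Nc3ccccc3N)cc2)CC1` gives 36.6%, the highest of the three numbers, although each step separating it from the other two lies within the usual scatter: a number 4.4 percentage points higher from compound 1 to compound 3 (within the scatter) and a number 8.5 percentage points higher from compound 2 to compound 3 (within the scatter). Compound 4 `Nc1ccccc1NC(=O)c1ccc(CSC(=S)N2CCN(Cc3ccccc3)CC2)cc1` differs from compound 3 by phenyl in place of hydrogen on a saturated chain carbon bound to an amine nitrogen in a ring. The measured steps that bear on this change are the two in which the group on the same amine nitrogen in a ring was exchanged, 4-chlorophenyl or 4-methoxyphenyl giving way to methyl, and both shifted the read-out by amounts within the scatter, as did a number 4.1 percentage points lower from compound 1 to compound 2 (within the scatter). In this assay a step no larger than the scatter, in no particular direction, is therefore expected for compound 4, whose number is estimated at 34%, within a range of 22% to 46%, corresponding to an expected step of a number 2.6 percentage points lower from compound 3 to compound 4 (within the scatter).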

Compound 4, a percentage reported as inhibition, at one concentration (the size of the read-out at that concentration, not a potency): 10.6%
Compound 4: the middle estimate sits 23.4 percentage points above what was measured; the whole stated range lies above it.
By their numbers in this assay, from the lowest: compound 4; then compounds 2, 1 and 3 (each within the scatter of the next).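

Among the compounds shown here, exchanging methyl, 4-chlorophenyl and 4-methoxyphenyl on the amine nitrogen in the ring had moved the read-out only within the scatter, but benzyl in place of methyl gives (a number 26 percentage points lower from compound 3 to compound 4 (beyond the scatter)) in this assay, the first change at this position to exceed it. The comparisons with the two directly attached aromatic groups agree, with (a number 17.5 percentage points lower from compound 2 to compound 4 (beyond the scatter)) and (a number 21.6 percentage points lower from compound 1 to compound 4 (beyond the scatter)), so this position does not tolerate every group equally, and a benzyl group behaves differently here from the aromatic groups tested. Nothing measured here explains this drop.

The compounds shown leave open whether the drop is particular to benzyl or also appears with a 2-phenylethyl chain, a plain ethyl group or a 4-chlorobenzyl group. A single tested concentration also leaves the potency of each compound open.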